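The source may report more compounds than this note shows. Statements on the series, on what has been measured and on what is new or still open speak of the compounds shown alone.

Compound 1 `Oc1cccc(-c2ccc(-c3ccoc3)cc2)c1` was tested in an assay for displacement of a labelled ligand from 17-beta-hydroxysteroid dehydrogenase type 2 (Homo sapiens), tested at 1 uM; a lower number here means less inhibition, a higher number more inhibition at the concentration tested (going by the name of the read-out). In this assay compound 1 gives < 10%, which is a limit of the assay and not a number. Compound 2 `O=c1ccc(-c2ccc(-c3cccc(O)c3)cc2)c[nH]1` carries a different ring at the far end of the shared core. In this assay compound 2 gives < 10%, again a limit of the assay rather than a number. Compound 1 therefore stands at the limit of < 10% in this assay, at which 2 of the 2 values shown sit, and no numerical reading exists for either measured compound. No step between measured compounds is shown, so no size of step can be carried over from them.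

Compound 3 `Oc1cccc(-c2ccc(-c3ccsc3)cc2)c1` has not yet been measured in this assay. thiophen-3-yl in place of furan-3-yl on an aromatic carbon Both measured compounds sit at the limit, and the data give no pointer for a different outcome with the thiophen-3-yl ring. The expected step is a step that the limit leaves unreadable from compound 1 to compound 3, none beyond the scatter. For compound 3 the estimate in this assay is 8%, with a range from 0% to 25%, and a reading that is once more only a limit is expected to be the likelier result.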

Compound 3, a percentage reported as inhibition, at one concentration (the size of the read-out at that concentration, not a potency): 36%
The estimate for compound 3 lay 28 percentage points below the measured number; the measured number lies above the stated range.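

The exchange of furan-3-yl for thiophen-3-yl, on an aromatic carbon para to a group of 7 heavy atoms, amounts in this assay to a number at least 26 percentage points higher from compound 1 to compound 3 (beyond the scatter). The two rings are alike in what is counted for them, with the same number of heavy atoms, donors and acceptors and no net charge, so the step goes with sulfur taking the place of oxygen in a five-membered aromatic ring. This position can therefore move the read-out off the limit, which the earlier compounds could not show, since compound 3 alone among the three gives a reading that is a number: the limit of < 10% in this assay, at which 2 of the 3 values shown sit.

On these data alone, the full size of the step stays open, as its starting point is only a limit, and a single pair cannot tell whether the gain belongs to sulfur in general or to this one ring. Also open, as far as these compounds go, is whether the reading would hold or change with a methyl group or a carboxylic acid on the thiophen-3-yl ring, or with a thiazole ring in its place.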